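Trading the methionine-type side chain for a glycine unit

This account rests on a few compounds, and the source may have more. Where it says the series, first, only, none or still open, it means among the compounds named here.

Of the compounds shown here, three sharing one core have been tested in a functional assay (HSMC cells, Homo sapiens) for antiproliferative activity, with a stated time of 72 h; on this read-out lower numbers stand for stronger inhibition and higher numbers for weaker inhibition. Compound 1 `COC(=O)[C@H](CCSC)NC(=O)c1ccc(OC[C@H]2COc3ccccc3O2)cc1-c1ccccc1OC` gives 230000 nM, and compound 2 `COC(=O)CNC(=O)c1ccc(OC[C@@H]2COc3ccccc3O2)cc1-c1ccccc1OC` gives 35000 nM. Compound 3 `COC(=O)[C@H](CCSC)NC(=O)c1ccc(C(=O)NC[C@@H]2COc3ccccc3O2)cc1-c1ccccc1OC`, which carries an amide link instead of the ether of the first two, gives 647000 nM; this is the highest of the three numbers, with compound 1 the nearest and compound 2 the furthest from it, both gaps lying beyond the usual scatter.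

Compound 4 `COC(=O)CNC(=O)c1ccc(C(=O)NC[C@@H]2COc3ccccc3O2)cc1-c1ccccc1OC` keeps the amide link of compound 3 and differs from it in one place: hydrogen in place of 2-(methylsulfanyl)ethyl on a saturated chain carbon bound to an amide-type nitrogen and a carbonyl carbon. Within the data shown here, no measured pair shows exactly this step. Compound 1 and compound 2 differ in the same side chain, although they also differ slightly elsewhere, and compound 2 sits at the markedly lower number of the two. On that basis a step in this assay from compound 3 to compound 4 of a 5.9-fold lower number from compound 3 to compound 4 (0.77 log units; beyond the scatter) toward a lower number is expected, clearly beyond the scatter. Compound 4 is therefore estimated at 110000 nM, within a range from 40000 nM to 300000 nM.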

Compound 4, half-maximal inhibitory concentration: 76000 nM
Compound 4: the middle estimate sits 1.4-fold (0.16 log units) above what was measured, within the range that was stated.
By their numbers in this assay, from the lowest: compound 2; then compound 4; then compound 1; then compound 3.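

Replacing 2-(methylsulfanyl)ethyl with hydrogen on the saturated chain carbon bound to an amide-type nitrogen and a carbonyl carbon gives, in this assay, an 8.5-fold lower number from compound 3 to compound 4 (0.93 log units; beyond the scatter). Compound 1 and compound 2 only hinted at this side-chain effect, since they also differ elsewhere, whereas here the change stands alone with the rest of the structure held constant. This position therefore responds to the change, and the 2-(methylsulfanyl)ethyl group is not needed for compound 4 to give 76000 nM.

Nothing shown gives a reason for this shift. From the compounds shown here alone, it remains open whether a methyl group, a longer chain, or a chain ending in an amine or a carboxylic acid on this carbon would give a lower or a higher number than hydrogen.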